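Ester to ether on the hydroxymethyl arm

The source may hold more compounds than are shown below. What is called first, only, known or untested is meant among the compounds shown, and "the series" means these compounds.

Compound 3 `CN(C)CCC(=O)OCc1c(F)c(N)c2c(=O)cc(-c3ccc(N)c(F)c3)oc2c1F` gives the lowest of the two numbers seen in a functional assay on HeLa cells (Homo sapiens) for cytotoxicity, read by neutral red uptake, with a stated time of 3 days (on this read-out higher numbers stand for weaker inhibition and lower numbers for stronger inhibition), namely 11000 nM. Its nearest neighbour is compound 2 `Nc1ccc(-c2cc(=O)c3c(N)c(F)c(CO)c(F)c3o2)cc1F`, which in this assay gives 24000 nM, and the measured step reads a 2.2-fold lower number from compound 2 to compound 3 (0.34 log units; beyond the scatter). Compound 1 `Nc1ccc(-c2cc(=O)c3c(N)c(F)c(Br)c(F)c3o2)cc1F` reaches only a limit in this assay, > 100000 nM. The same limit is recorded as the limit of > 100000 nM in this assay, at which 1 of the 3 values shown sits. Compound 4 `CN(C)CCCOCc1c(F)c(N)c2c(=O)cc(-c3ccc(N)c(F)c3)oc2c1F` differs from compound 3 by 3-(dimethylamino)propyl in place of (2-(dimethylamino)ethyl)carbonyl on an oxygen on a saturated carbon. For the measured compounds named here, no measured step swaps an ester for an ether at this oxygen; the closest guide is a 2.2-fold lower number from compound 2 to compound 3 (0.34 log units; beyond the scatter), which shows what attaching the basic arm did. For compound 4 the expected step of no change at the digits printed from compound 3 to compound 4 (within the scatter) is therefore small, within the scatter. Compound 4 is estimated at 11000 nM, between 4000 nM and 30000 nM.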

Compound 4, half-maximal inhibitory concentration: 12000 nM
Beside the measured number, compound 4's estimate is 1.1-fold (0.04 log units) below it; the range from low to high includes it.
By their numbers in this assay, from the lowest: compounds 3, 4 and 2 (each within the scatter of the next, the first and the last beyond it). At a limit, above all of these: compound 1.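

Replacing the ester arm with the ether arm leaves the number in this assay unchanged within the scatter (a 1.1-fold higher number from compound 3 to compound 4 (0.04 log units; within the scatter)), so at this oxygen the arm's carbonyl is not required for the value seen with compound 3. Attaching the ether arm to the free hydroxymethyl gives a step that also stays within the scatter (a 2.0-fold lower number from compound 2 to compound 4 (0.30 log units; within the scatter)). Compound 1 stands at a limit, so its step is only a bound (an at least 8.3-fold lower number from compound 1 to compound 4 (0.92 log units; beyond the scatter)): the limit of > 100000 nM in this assay, at which 1 of the 4 values shown sits.

The compounds shown leave open whether a morpholine in place of the dimethylamino group would move the number. They also leave open what an amide linkage or a longer chain at this position would do.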